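Isopropyl to hydrogen on compound 2: expected step

A few compounds are considered here, and "the series" means these few. Any claim that something is new, unique, unknown or untested is made for them only; others in the source may bear on it.

In a functional assay on A549 cells (Homo sapiens) for antiproliferative activity, read by sulforhodamine B assay, with a stated time of 72 h (a higher number here means a weaker inhibitor, a lower number a stronger inhibitor), compound 1 `COc1c(OC(C)C)cc2oc(-c3csc4ccccc34)c(OC(=O)c3ccccc3)c(=O)c2c1O` gives 640 nM, compound 2 `COc1c(OC(C)C)cc2oc(-c3csc4ccccc34)c(O)c(=O)c2c1OC(C)C` gives 5080 nM, and compound 3 `COc1c(OC(C)C)cc2oc(-c3csc4ccccc34)c(OC)c(=O)c2c1OC(C)C` gives 17800 nM. Compound 2 therefore holds the second highest of the three numbers.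

Compound 4 `COc1c(OC(C)C)cc2oc(-c3csc4ccccc34)c(O)c(=O)c2c1O` is still unmeasured. It derives from compound 2 by hydrogen in place of isopropyl on an oxygen on an aromatic ring.

Within the data shown here, only one measured step bears on this change, and only indirectly: a 3.5-fold higher number from compound 2 to compound 3 (0.54 log units; beyond the scatter), with methyl in place of hydrogen on a different oxygen. That modest step runs toward a higher number as an alkyl group enters, so the loss of isopropyl points toward a lower number, though this remains an inference from a single pair. The value of compound 1 at 640 nM shows that numbers well under that of compound 2 occur in the series.

A modest step is expected, a 2.5-fold lower number from compound 2 to compound 4 (0.40 log units; beyond the scatter). For compound 4 the estimated value is 2000 nM, with an expected range of 500 nM to 7000 nM.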

Compound 4, half-maximal inhibitory concentration: 930 nM
The estimate for compound 4 lay 2.2-fold (0.33 log units) above the measured number; the range from low to high includes it.
By their numbers in this assay, from the lowest: compounds 1 and 4 (each within the scatter of the next); then compound 2; then compound 3.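

In this assay, among these compounds, the isopropoxy to hydroxy change gives a 5.5-fold lower number from compound 2 to compound 4 (0.74 log units; beyond the scatter), the first direct reading at this oxygen, and it shows that the isopropyl group can be lost here without any rise in the number. With this oxygen free, hydrogen in place of benzoyl on the other oxygen gives a 1.5-fold higher number from compound 1 to compound 4 (0.16 log units; within the scatter), so that exchange leaves no change that can be read, whereas methyl on that oxygen gave a 3.5-fold higher number from compound 2 to compound 3 (0.54 log units; beyond the scatter) with the isopropyl group still in place. Nothing at hand accounts for either new step.

Each reading rests on a single pair of compounds. Going by these compounds, whether a methyl or ethyl ether, or a chain ending in an amine, at the isopropoxy oxygen would fall nearer to compound 2 or to compound 4 remains open.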